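The compounds below may be only part of what the source reports. "The series", "measured", "known", "first", "only" and "open" are said of these compounds alone.

Measured compounds in a functional assay on PC-3 cells (Homo sapiens) for cytotoxicity, read by MTT assay, with a stated time of 72 h; on this read-out higher numbers stand for weaker inhibition and lower numbers for stronger inhibition: compound 1, `COc1ccc(/C=C/C(=O)Nc2cc(C(=O)c3cc(OC)c(OC)c(OC)c3)ccc2OC)cc1`, gives 11100 nM; compound 2, `COc1cccc(/C=C/C(=O)Nc2cc(C(=O)c3cc(OC)c(OC)c(OC)c3)ccc2OC)c1`, gives 4700 nM.

Within the data shown here, compound 2 stands lowest of the two numbers so far; its nearest neighbour is compound 1, and the step from the one to the other, a 2.4-fold lower number from compound 1 to compound 2 (0.37 log units; beyond the scatter), comes from placing 3-methoxyphenyl in place of 4-methoxyphenyl on a double-bonded chain carbon bound to a double-bonded chain carbon.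

Compound 3, `C#CCOc1cccc(/C=C/C(=O)Nc2cc(C(=O)c3cc(OC)c(OC)c(OC)c3)ccc2OC)c1`, differs from compound 2 by ethynyl in place of hydrogen on a saturated chain carbon bound to an oxygen on an aromatic ring; cut one bond further out, this reads methoxy to propargyloxy, or 3-methoxyphenyl to 3-(propargyloxy)phenyl. Among the measured compounds shown here, none of the measured steps touches the group on the oxygen on the aromatic ring; the single measured step, a 2.4-fold lower number from compound 1 to compound 2 (0.37 log units; beyond the scatter), moves the methoxy group between ring positions and does not lengthen it. For the measured compounds named here, there is therefore no measured step that bears directly on this change, and the expectation for compound 3 is a step of about a 1.0-fold lower number from compound 2 to compound 3 (0.02 log units; within the scatter) in this assay, that is, no change beyond the scatter. On that basis compound 3 is estimated at 4500 nM, with a range from 1500 nM to 13000 nM.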

Compound 3, half-maximal inhibitory concentration: 13100 nM
Beside the measured number, compound 3's estimate is 2.9-fold (0.46 log units) below it; measured number outside the range, above it.
By their numbers in this assay, from the lowest: compound 2; then compounds 1 and 3 (each within the scatter of the next).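

In this assay, the group on the oxygen on the aromatic ring proves sensitive to change: going from methoxy to propargyloxy gives a clear step (a 2.8-fold higher number from compound 2 to compound 3 (0.45 log units; beyond the scatter)), whereas the earlier step only moved a methoxy group and left it the same size. The advantage that compound 2 held over compound 1 does not carry over to the longer group, since 3-(propargyloxy)phenyl in place of 4-methoxyphenyl gives only a 1.2-fold higher number from compound 1 to compound 3 (0.07 log units; within the scatter), and on this read-out compound 3 and compound 1 cannot be told apart. Nothing measured here accounts for the step from methoxy to propargyloxy.

The compounds shown leave open whether this step follows from the triple bond or simply from the longer chain on the oxygen; a propyl group at this place would separate the two. Going by these compounds, how an amine or a carboxylic acid on the saturated chain carbon bound to the oxygen on the aromatic ring would read in this assay also remains open.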